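The compounds below may be only part of what the source reports. "The series", "measured", "known", "first", "only" and "open" are said of these compounds alone.

Compound 1 `C=C/C(C)=C/C=C/C(C)(O)CCC=C(C)C` and compound 2 `C=C/C(C)=C\C=C\C(C)CC(=O)CC(C)C` were both tested in a functional assay on HT-29 cells (Homo sapiens) for cytotoxicity; on this read-out higher numbers stand for weaker inhibition and lower numbers for stronger inhibition. Compound 1 gives 2.5 ug/mL there. Compound 2 gives 2.5 ug/mL, level with compound 1 at the digits shown, so the two sit within the usual scatter of each other. Compound 3 `CC(C)=C/C=C\C(C)/C=C/C=C(\C)C=O` reaches only a limit in this assay, > 10 ug/mL, and no number is known for it; the limit of > 10 ug/mL in this assay, at which 1 of the 3 values shown sits, records that one of the three values is such a limit. Compound 4 `C=C/C(C)=C/C=C/C(C)CC(=O)CC(C)C` has not yet been measured. It differs from compound 2 in this way: the two compounds have the same atoms and bonds; at least one stereo element is drawn with a configuration in one of them and without one in the other: 1 of 3 stereo elements differ; a double bond is drawn Z in compound 2 and E in compound 4. Among the compounds with values here, no measured step between compounds differing in one place exists here, so the expectation is no change beyond the scatter. Compound 4 is therefore expected to give 2.5 ug/mL, between 1.2 ug/mL and 5.5 ug/mL. The expected step is no change at the digits printed from compound 2 to compound 4 (within the scatter), within the scatter.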

Compound 4, half-maximal inhibitory concentration: 5 ug/mL
The estimate for compound 4 lay 2.0-fold (0.30 log units) below the measured number; the range from low to high includes it.
By their numbers in this assay, from the lowest: compounds 1, 2 and 4 (each within the scatter of the next). At a limit, above all of these: compound 3.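

Within the data shown here, the step of a 2.0-fold higher number from compound 2 to compound 4 (0.30 log units; within the scatter) in this assay is the first comparison here that isolates a single difference, the drawn geometry of one double bond, Z or E. Compound 2 and compound 4 therefore cannot be told apart on this read-out, which the earlier compounds could not show. That reading has one limitation, since the stereo drawing is not equally complete in the pair: the fact that one of compounds 2 and 4 is drawn with a defined configuration and the other without, at the place where they differ.

From the compounds shown here alone, whether an amine or a carboxylic acid in place of the carbonyl would give a different number remains open. So does the effect of a longer chain.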